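The source may report more compounds than this note shows. Statements on the series, on what has been measured and on what is new or still open speak of the compounds shown alone.

The measured compounds, each tested in an ADME assay on cells (Splenocyte, Mus musculus, strain BALB/c) for cytotoxicity, read by CCK-8 assay, with a stated time of 48 h; a lower number here means that less compound is tolerated, a higher number that more compound is tolerated:

Compound 1, `COc1cc(-c2nc(Cc3c[nH]c4ccccc34)no2)cc(OC)c1OC`: compound 1 gives > 50000 nM, which is a limit of the assay rather than a number.
Compound 2, `COc1cc(-c2noc(-c3ccccc3)n2)cc(OC)c1OC`: compound 2 gives > 50000 nM, again a limit rather than a number.
Compound 3, `COc1cc(-c2noc(-c3cccc(N)c3)n2)cc(OC)c1OC`: compound 3 gives 8200 nM.

Compound 2 thus stands at the limit of > 50000 nM in this assay, at which 2 of the 3 values shown sit, so its true value is not known, only that it lies beyond that mark. Compound 4, `CCCCc1ccc(-c2nc(-c3cc(OC)c(OC)c(OC)c3)no2)cc1`, differs from compound 2 in one place: butyl in place of hydrogen on an aromatic carbon. Among the measured compounds shown here, the only measured step that starts from compound 2 is an at least 6.0-fold lower number from compound 2 to compound 3 (0.78 log units; beyond the scatter). That step brings in an amino group, not a butyl chain, so it shows that a single substituent added to compound 2 can lower the number beyond the scatter, but it says nothing specific about butyl. With no closer comparison available, the expectation for compound 4 is a step of an at least 1.2-fold lower number from compound 2 to compound 4 (0.09 log units; that floor lies within the scatter), small and within the scatter, with a result that is again only a limit remaining a real possibility. Compound 4 is therefore estimated at 40000 nM, with a range from 15000 nM to 100000 nM.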

Compound 4, half-maximal cytotoxic concentration: 21200 nM
The estimate for compound 4 lay 1.9-fold (0.28 log units) above the measured number; the measured number falls inside the stated range.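

Until now, only the amino group of compound 3 had lowered the number from compound 2 beyond the scatter. In this assay, butyl on an aromatic carbon of the six-membered aromatic ring of carbon only, para to a large group, gives an at least 2.3-fold lower number from compound 2 to compound 4 (0.37 log units; beyond the scatter), so a chain of carbon alone at this position also lowers the number, and compound 4 gives 21200 nM, a measured number rather than a limit. The true size of this step remains unknown, and the printed size is only its smallest possible value, because compound 2 is known only as a limit: the limit of > 50000 nM in this assay, at which 2 of the 4 values shown sit.

Going by these compounds, whether the number depends on the length of the chain remains open, as a methyl group, a longer chain such as hexyl, or a carboxylic acid at this same place would be needed to show it. Also open, on these data alone, is whether butyl would give the same result on the ring carbon that carries the amino group in compound 3, and what an amino group would do at the place that carries butyl in compound 4.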